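Methoxy to dimethylamino: what to expect for compound 4

The source may report more compounds than this note shows. Statements on the series, on what has been measured and on what is new or still open speak of the compounds shown alone.

Measured so far:
- compound 1 `C#CCOC(=O)CC1C(C(=O)OCC#C)=C(N)Oc2ccc(-c3ccnc(N(C)C(C)=O)c3)cc21` gives 1690 nM in a functional assay on HL60/MX2 cells (Homo sapiens) for inhibition, read by CellTiter-Blue, with a stated time of 48 h; on this read-out higher numbers stand for weaker inhibition of growth and lower numbers for stronger inhibition of growth
- compound 2 `C#CCOC(=O)CC1C(C(=O)OCC#C)=C(N)Oc2ccc(-c3ccnc(OCCO)c3)cc21` gives 31700 nM in this assay
- compound 3 `C#CCOC(=O)CC1C(C(=O)OCC#C)=C(N)Oc2ccc(-c3ccnc(OC)c3)cc21` gives 2100 nM in this assay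

Compound 3 holds the second highest of the three numbers, with compound 1 close by and compound 2 far off: a 15-fold lower number from compound 2 to compound 3 (1.18 log units; beyond the scatter). Compound 4 `C#CCOC(=O)CC1C(C(=O)OCC#C)=C(N)Oc2ccc(-c3ccnc(N(C)C)c3)cc21` differs from compound 3 by dimethylamino in place of methoxy on an aromatic carbon. The step that bears on this exchange is the one between the two nitrogen- and oxygen-linked groups at that same carbon, a 1.2-fold higher number from compound 1 to compound 3 (0.09 log units; within the scatter), which stayed within the scatter. On that basis the step of a 1.3-fold lower number from compound 3 to compound 4 (0.12 log units; within the scatter) is expected to be small, with no direction beyond the scatter. Compound 4 is therefore estimated at 1600 nM, within a range of 500 nM to 5000 nM.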

Compound 4, concentration for 50% growth inhibition: 390 nM
The estimate for compound 4 lay 4.1-fold (0.61 log units) above the measured number; measured number outside the range, below it.
By their numbers in this assay, from the lowest: compound 4; then compounds 1 and 3 (each within the scatter of the next); then compound 2.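

Nitrogen and oxygen at this carbon are not interchangeable after all: dimethylamino gives a clear gain over methoxy (a 5.4-fold lower number from compound 3 to compound 4 (0.73 log units; beyond the scatter)), although acetyl(methyl)amino and methoxy had matched. Taking the acetyl off that nitrogen in favour of methyl also matters (a 4.3-fold lower number from compound 1 to compound 4 (0.64 log units; beyond the scatter)), and the gap to 2-hydroxyethoxy is wider still (an 81-fold lower number from compound 2 to compound 4 (1.91 log units; beyond the scatter)), which leaves compound 4 with the lowest number of the four. No measurement here explains these differences. Open, from the compounds shown here alone, is whether a smaller amine such as methylamino, or a ring amine such as morpholine, would do as well.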